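Nitrofuran in Place of Hydroxyphenyl: Vero Cell Tolerance

The source may hold more compounds than are shown below. What is called first, only, known or untested is meant among the compounds shown, and "the series" means these compounds.

Compound 1 `O=[N+]([O-])c1ccccc1/C=N\NC(=S)N(Cc1ccccc1)Cc1ccccc1` gives < 155000 nM in an ADME assay on Vero cells (Chlorocebus sabaeus) for cytotoxicity, read by MTT assay, with a stated time of 72 h; a lower number here means that less compound is tolerated, a higher number that more compound is tolerated; this is a limit, not a number.
Compound 2 `Cc1ccccc1/C=N\NC(=S)N(Cc1ccccc1)Cc1ccccc1` gives 167000 nM in this assay.
Compound 3 `Oc1ccccc1/C=N\NC(=S)N(Cc1ccccc1)Cc1ccccc1` gives 166000 nM in this assay.

Compound 3 sits level with compound 2, the two values lying within the scatter of each other, as the step of a 1.0-fold lower number from compound 2 to compound 3 (0.00 log units; within the scatter) shows. For the measured compounds named here, the only other measured compound, compound 1, offers a limit rather than a number, so no ordering of compound 3 against it can be drawn.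

Compound 4 `O=[N+]([O-])c1ccc(/C=N\NC(=S)N(Cc2ccccc2)Cc2ccccc2)o1` is not yet measured. The change from compound 3 is 5-nitrofuran-2-yl in place of 2-hydroxyphenyl on a carbon with a double bond to nitrogen. Going by the values given here, three measured steps bear on this: an at least 1.0-fold higher number from compound 1 to compound 2 (0.03 log units; that floor lies within the scatter), an at least 1.0-fold higher number from compound 1 to compound 3 (0.02 log units; that floor lies within the scatter) and a 1.0-fold lower number from compound 2 to compound 3 (0.00 log units; within the scatter). All three lie within the scatter, and the one that touches a nitro group, the step from compound 1, rests on the limit of < 155000 nM in this assay, at which 1 of the 3 values shown sits, and so gives only a floor. From the compounds shown here alone, none of them covers a change of the ring itself, and the effect of a five-membered aromatic ring with one hetero atom in this position is untested here. With the measured steps all small, compound 4 is expected to sit near compound 3, with a wide range to cover the untested ring swap and the possibility of a lower number as hinted by the limit on compound 1. The estimate for compound 4 is 100000 nM, between 30000 nM and 250000 nM, which would mean a step of a 1.7-fold lower number from compound 3 to compound 4 (0.22 log units; within the scatter).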

Compound 4, half-maximal cytotoxic concentration: 158000 nM
For compound 4 the middle estimate is 1.6-fold (0.20 log units) below the measured one; the range from low to high includes it.
By their numbers in this assay, from the lowest: compounds 4, 3 and 2 (each within the scatter of the next). At a limit, below all of these: compound 1.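

For the compounds shown here, until this result, the changes on the shared core had swapped only a group on the six-membered aromatic ring, whereas here the ring itself gives way to a five-membered aromatic ring with one hetero atom. In this assay, this larger change stays within the scatter against both neighbours (a 1.1-fold lower number from compound 3 to compound 4 (0.02 log units; within the scatter); a 1.1-fold lower number from compound 2 to compound 4 (0.02 log units; within the scatter)), so among compounds 2, 3 and 4 this position shows no measurable sensitivity to the ring or to the group it carries. The step from the nitro-bearing six-membered ring gives only a floor (an at least 1.0-fold higher number from compound 1 to compound 4 (0.00 log units; that floor lies within the scatter)), and the value of compound 1 is a limit, not a number: the limit of < 155000 nM in this assay, at which 1 of the 4 values shown sits.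

What the compounds leave open is whether the ring and the nitro group each have no effect alone, or whether their effects merely offset each other, a question that plain furan-2-yl or a 5-aminofuran-2-yl group at the same place would address. From the compounds shown here alone, it is also open whether a carboxylic acid on the ring, or a longer chain such as phenylethyl in place of the two benzyl groups on the core, would move the number beyond the scatter.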